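A Basic Chain Replaces Cyclopropyl on Compound 2

The compounds below may be only part of what the source reports. "The series", "measured", "known", "first", "only" and "open" are said of these compounds alone.

Of the compounds shown here, three sharing one core have been measured in a functional assay on U-87MG ATCC cells for antiproliferative activity against U-87 MG (Homo sapiens), read by MTT assay, with a stated time of 72 h; on this read-out higher numbers stand for weaker inhibition and lower numbers for stronger inhibition. Compound 1 `COc1ncc(-c2ccc3nc(NC(=O)NCCN4CCCC4)sc3c2)cc1NS(=O)(=O)c1ccc(F)cc1` gives 360 nM. Compound 2 `COc1ncc(-c2ccc3nc(NC(=O)NC4CC4)sc3c2)cc1NS(=O)(=O)c1ccc(F)cc1` gives 520 nM, and compound 3 `O=C(Nc1nc2ccc(-c3cnc(Cl)c(NS(=O)(=O)c4ccc(F)cc4)c3)cc2s1)NC1CC1` gives 1720 nM. On these numbers compound 2 stands second highest of the three: the step of a 1.4-fold higher number from compound 1 to compound 2 (0.16 log units; within the scatter) lies within the scatter, while the step of a 3.3-fold higher number from compound 2 to compound 3 (0.52 log units; beyond the scatter) is modest but beyond it.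

Compound 4 `COc1ncc(-c2ccc3nc(NC(=O)NCCN4CCN(C)CC4)sc3c2)cc1NS(=O)(=O)c1ccc(F)cc1` has not yet been measured. It differs from compound 2 in one place: 2-(4-methylpiperazin-1-yl)ethyl in place of cyclopropyl on an amide-type nitrogen. Going by the values given here, the one measured step that bears on this change is the one at the same amide-type nitrogen, a 1.4-fold higher number from compound 1 to compound 2 (0.16 log units; within the scatter), where 2-(pyrrolidin-1-yl)ethyl gave way to cyclopropyl and the number moved only within the scatter. Compound 4 reverses that direction with a different chain, 2-(4-methylpiperazin-1-yl)ethyl in place of cyclopropyl. Among the compounds with values here, no measured compound carries this exact group, so the expectation rests on that single step. A small move toward a lower number, or none beyond the scatter, is therefore expected, a 1.4-fold lower number from compound 2 to compound 4 (0.14 log units; within the scatter). Compound 4 is estimated at 380 nM, with a range from 180 nM to 800 nM in this assay.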

Compound 4, half-maximal inhibitory concentration: 440 nM
For compound 4 the middle estimate is 1.2-fold (0.06 log units) below the measured one, and the stated range covers the measured number.
By their numbers in this assay, from the lowest: compounds 1, 4 and 2 (each within the scatter of the next); then compound 3.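

In this assay, the amide-type nitrogen accepts a second, larger basic-free-named chain without a shift beyond the scatter: a 1.2-fold lower number from compound 2 to compound 4 (0.07 log units; within the scatter), with 2-(4-methylpiperazin-1-yl)ethyl in place of cyclopropyl.

Correction of wording in the final text follows.

In this assay, the amide-type nitrogen takes a second, larger chain with no shift beyond the scatter: the change to 2-(4-methylpiperazin-1-yl)ethyl from cyclopropyl gives a 1.2-fold lower number from compound 2 to compound 4 (0.07 log units; within the scatter). The ring at the end of the chain can be exchanged in the same way, since 4-methylpiperazin-1-yl in place of pyrrolidin-1-yl gives a 1.2-fold higher number from compound 1 to compound 4 (0.09 log units; within the scatter). Cyclopropyl and both chains thus sit within the scatter of one another at this nitrogen, while the one step shown beyond the scatter lies elsewhere on the molecule, chloro in place of methoxy, at a 3.3-fold higher number from compound 2 to compound 3 (0.52 log units; beyond the scatter). Nothing available explains why this position responds so little to such different groups. On these data alone, what remains open is whether a morpholine-bearing chain, a primary amine, a carboxylic acid or a longer chain at this nitrogen would stay equally flat, and whether either basic-free cyclopropyl alternative, the 2-(pyrrolidin-1-yl)ethyl or 2-(4-methylpiperazin-1-yl)ethyl chain, would behave the same way alongside chloro, which appears here only with cyclopropyl.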